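The source may report more compounds than this note shows. Statements on the series, on what has been measured and on what is new or still open speak of the compounds shown alone.

Three compounds have been measured in an assay on HEK293 cells for displacement of a labelled ligand from Melanocortin receptor 4 (Homo sapiens); on this read-out lower numbers stand for stronger inhibition and higher numbers for weaker inhibition:

compound 1, `Cc1ccc(OCC(=O)N2CCN(c3ccc(C(F)(F)F)cc3[C@@H](N)CC(C)C)CC2)cc1`, 4400 nM
compound 2, `CC(C)C[C@H](N)c1cc(F)ccc1N1CCN(C(=O)C(C)Cc2ccc(Cl)cc2)CC1`, 390 nM
compound 3, `Cc1ccc(N2CCN(C(=O)[C@H](C)Cc3ccc(Cl)cc3F)CC2)c([C@@H](N)CC(C)C)c1`, 20 nM

Compound 1 gives the highest number of the three. Compound 2 lies clearly below it, by a gap beyond the usual scatter, and compound 3 lies far lower still, so compound 1 is the weakest binder in this small set. Compounds 2 and 3 differ from compound 1 in several places at once, so their values show only that other linkers between the core and the outer aromatic ring reach much lower numbers; they do not isolate any single change.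

The next compound, compound 4, `CC(C)C[C@H](N)c1cc(C(F)(F)F)ccc1N1CCN(C(=O)COc2cccc3ccccc23)CC1`, differs from compound 1 in one place:

naphthalen-1-yl in place of 4-methylphenyl on an oxygen on a saturated carbon

Among the compounds with values here, no measured pair shows this kind of change, so the size of its effect is not known from the data. Compound 1 is expected to improve only modestly in this assay, with a 1.8-fold lower number from compound 1 to compound 4 (0.25 log units; within the scatter), a step that may not exceed the scatter. Compound 4 is estimated at 2500 nM, within a range from 600 nM to 10000 nM.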

Compound 4, inhibition constant: 2600 nM
Compound 4: the middle estimate sits 1.0-fold (0.02 log units) below what was measured, within the range that was stated.
By their numbers in this assay, from the lowest: compound 3; then compound 2; then compounds 4 and 1 (each within the scatter of the next).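

In this assay, within the data shown here, the swap of 4-methylphenyl for naphthalen-1-yl on an oxygen on a saturated carbon gives a 1.7-fold lower number from compound 1 to compound 4 (0.23 log units; within the scatter) and is the first change in the set that can be read in one place. With the rest of the molecule held constant, this position takes a second six-membered aromatic ring of carbon only, and 10 heavy atoms in place of 7, with no step beyond the scatter. No supporting data at hand bear on this result.

The compounds shown leave open whether an amine or a carboxylic acid on the outer ring, or a longer chain ahead of it, would move the number beyond the scatter. They also leave open whether naphthalen-1-yl would behave the same way on a different linker.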